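The source may report more compounds than this note shows. Statements on the series, on what has been measured and on what is new or still open speak of the compounds shown alone.

Of the compounds shown here, two sharing one core have been measured in a functional assay on HeLa cells (Homo sapiens) for inhibition, read by MTT assay, with a stated time of 24 h, tested at 10 uM; on this read-out lower numbers stand for less inhibition of growth and higher numbers for more inhibition of growth at the one concentration tested. Compound 1 `N#Cc1ccc(-c2cnc3[nH]cc(-c4nnc(-c5ccc(Cl)cc5)o4)c(=O)c3c2)cc1` gives 13.7% in this assay. Compound 2 `CS(=O)(=O)c1ccc(-c2cnc3[nH]cc(-c4nnc(-c5ccc(F)cc5)o4)c(=O)c3c2)cc1` gives 15.7% in this assay; on the numbers shown, compound 2 stands together with compound 1, the gap between the two lying within the usual scatter, so the two cannot be told apart on this read-out. Compound 3 `Cc1cccc(-c2nnc(-c3c[nH]c4ncc(-c5ccc(S(C)(=O)=O)cc5)cc4c3=O)o2)c1` has not yet been measured in this assay. It differs from compound 2 in one place: 3-methylphenyl in place of 4-fluorophenyl on an aromatic carbon. Within the data shown here, no step between measured compounds bears on such a change, so what can be said of compound 3 rests on the values of compound 1 and compound 2 alone. In this assay the step of a number 0.7 percentage points lower from compound 2 to compound 3 (within the scatter) is expected to be small, in no clear direction and not beyond the scatter. Compound 3 is therefore estimated to give 15% in this assay, with a range from 5% to 30%.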

Compound 3, percent growth inhibition at one concentration: 2.57%
For compound 3 the middle estimate is 12.4 percentage points above the measured one, and the stated range ends above it.
By their numbers in this assay, from the lowest: compound 3; then compounds 1 and 2 (each within the scatter of the next).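

In this assay, putting 3-methylphenyl in place of 4-fluorophenyl on an aromatic carbon of the five-membered aromatic ring with 2 nitrogen and 1 oxygen gives a number 13.1 percentage points lower from compound 2 to compound 3 (beyond the scatter) and so shows that this position responds to a change of its aryl group. The two groups have the same number of heavy atoms and no hydrogen-bond donors or acceptors, so those counts do not separate them. Compound 1 and compound 2 differ in more than one place and could not show this, and no measurement at hand bears on the reason for the step.

From the compounds shown here alone, whether the lower number goes with the methyl group, its place on the phenyl ring or the absence of fluorine remains open. Going by these compounds, how an amine or a carboxylic acid on this phenyl ring would read out also remains open.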